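Moving the nitro group around the ring in compound 3

The source may report more compounds than this note shows. Statements on the series, on what has been measured and on what is new or still open speak of the compounds shown alone.

Measured so far:
Compound 1, `Fc1cccc(F)c1NCn1nc(-c2ccc3c(c2)OCCO3)oc1=S`, gives 3320 nM.
Compound 2, `S=c1oc(-c2ccc3c(c2)OCCO3)nn1CNc1ccc(Cl)c(Cl)c1`, gives 6840 nM.
Compound 3, `O=[N+]([O-])c1ccccc1NCn1nc(-c2ccc3c(c2)OCCO3)oc1=S`, gives 10900 nM.

All three share one core and differ only in the aryl group on the amine nitrogen. In a functional assay, with a stated time of 6 min (on this read-out lower numbers stand for stronger inhibition and higher numbers for weaker inhibition), compound 3 stands highest of the three, with compound 2 nearest, a step within the scatter, and compound 1 furthest, as the step of a 3.3-fold higher number from compound 1 to compound 3 (0.52 log units; beyond the scatter) shows; the step of a 2.1-fold higher number from compound 1 to compound 2 (0.31 log units; beyond the scatter) is also beyond the scatter, while a 1.6-fold higher number from compound 2 to compound 3 (0.20 log units; within the scatter) is not.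

Compound 4, `O=[N+]([O-])c1cccc(NCn2nc(-c3ccc4c(c3)OCCO4)oc2=S)c1`, keeps the same atoms joined differently: 3-nitrophenyl in place of 2-nitrophenyl on an amine nitrogen. Going by the values given here, none of the measured steps moves a single group around a ring; each swaps one aryl group for a different one, so no step bears directly on this change. The values of compound 1 and compound 2 only show that a range of aryl groups sits within a narrow band here. The step of a 1.4-fold lower number from compound 3 to compound 4 (0.13 log units; within the scatter) is therefore expected to stay small. Compound 4 is estimated at 8000 nM, within 3000 nM to 25000 nM.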

Compound 4, half-maximal inhibitory concentration: 8870 nM
For compound 4 the middle estimate is 1.1-fold (0.04 log units) below the measured one; the measured number falls inside the stated range.
By their numbers in this assay, from the lowest: compound 1; then compounds 2, 4 and 3 (each within the scatter of the next).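

In this assay the move from 2-nitrophenyl to 3-nitrophenyl on the amine nitrogen gives a 1.2-fold lower number from compound 3 to compound 4 (0.09 log units; within the scatter) and so leaves the read-out unchanged within the scatter, which means that at this position, for these two compounds, where the nitro group sits on the ring makes no measurable difference. Going by these compounds alone, the step of a 1.3-fold higher number from compound 2 to compound 4 (0.11 log units; within the scatter) also stays within the scatter, while a 2.7-fold higher number from compound 1 to compound 4 (0.43 log units; beyond the scatter) is the only new step beyond it, and a modest one. No measurement is available that explains these small differences.

All the aryl groups shown carry only chloro, fluoro or nitro groups, so it remains open whether an amine or a carboxylic acid on the phenyl ring would produce a larger step. Also open, as far as these compounds go, is what a longer chain would do in place of the saturated chain carbon on the amine nitrogen.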